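The source may report more compounds than this note shows. Statements on the series, on what has been measured and on what is new or still open speak of the compounds shown alone.

Two related compounds have been tested so far in a functional assay on L1210 cells (Mus musculus) for antiproliferative activity, with a stated time of 72 h; on this read-out lower numbers stand for an effect already at smaller amounts and higher numbers for an effect only at larger amounts of compound. Compound 1, `Cc1cn([C@@H]2O[C@H](CO)[C@@H](CF)[C@H]2O)c(=O)[nH]c1=O`, gives only a limit of the assay, > 100 uM. Compound 2, `Cc1cn([C@@H]2O[C@H](CO)[C@@H](CN)[C@@H]2O)c(=O)[nH]c1=O`, likewise gives only a limit, > 100 uM. All that can be said so far is the limit of > 100 uM in this assay, at which 2 of the 2 values shown sit. Compound 3, `Cc1cn([C@@H]2O[C@H](CO)[C@@H](CF)[C@@H]2O)c(=O)[nH]c1=O`, differs from compound 2 as follows: fluoro in place of amino on a saturated chain carbon bound to a saturated ring carbon. For the measured compounds named here, no measured step exists to lean on, and no shift beyond the usual scatter is expected in either direction. The estimated step is a number no higher from compound 2 to compound 3 (the limit leaves the size open). For compound 3 the expected value is 100 uM, with an estimated range of 40 uM to 200 uM.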

Compound 3, concentration for half-maximal effect: > 100 uM
Compound 3: no number, only a limit (the forecaster's own chance of this, stated with the estimate: 85%); the middle value sits exactly at the limit.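

For the compounds shown here, compound 3 gives only a limit, as do compound 1 and compound 2, so no step to compound 3 can be read. The compounds shown leave open whether fluoro in place of amino, or the change in configuration, alters activity at all.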